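This account rests on a few compounds, and the source may have more. Where it says the series, first, only, none or still open, it means among the compounds named here.

Measured in a functional assay on NCI-H1975 cells (Homo sapiens) for antiproliferative activity, read by CCK-8 assay, with a stated time of 72 h; a lower number here means a stronger inhibitor of growth, a higher number a weaker inhibitor of growth:
- compound 1 (`CC[C@@H]1C(=O)N(C)c2cnc(Nc3ccc(S(=O)(=O)NCCCO)cc3)nc2N1C1CCCC1`): 2140 nM
- compound 2 (`CCC1C(=O)N(C)c2cnc(-n3ccc4cc(F)ccc43)nc2N1c1ccn(C)n1`): 28600 nM
- compound 3 (`CC[C@@H]1C(=O)N(C)c2cnc(-n3ccc4cc(C(=O)NCC(C)C)ccc43)nc2N1C1CCCC1`): "not active" (no number reported)

Of the two compounds with a number, compound 2 has the higher one and is thus the weaker growth inhibitor, a gap beyond the scatter. Compound 4 (`CCC1C(=O)N(C)c2cnc(-n3ccc4cc(C(=O)NCC(C)C)ccc43)nc2N1c1ccn(C)n1`) has isobutylcarbamoyl in place of fluoro on an aromatic carbon of compound 2: isobutylcarbamoyl in place of fluoro on an aromatic carbon. Compound 3 also bears isobutylcarbamoyl, and compound 3 gives "not active" (no number reported), so no gain in this assay is expected. The expected change, a 1.4-fold lower number from compound 2 to compound 4 (0.16 log units; within the scatter), is estimated to stay within the scatter. For compound 4 the estimated value is 20000 nM, with an expected range of 5000 nM to 60000 nM.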

Compound 4, concentration for 50% growth inhibition: 10200 nM
Compound 4: the middle estimate sits 2.0-fold (0.29 log units) above what was measured; the range from low to high includes it.
By their numbers in this assay, from the lowest: compound 1; then compound 4; then compound 2.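

Swapping fluoro for isobutylcarbamoyl on this aromatic carbon gives in this assay a 2.8-fold lower number from compound 2 to compound 4 (0.45 log units; beyond the scatter) and so shows that this position accepts a much larger group, with a modest gain in growth inhibition. No measurement shown explains this gain.

As far as these compounds go, it remains open whether the gain depends on the amide or on the isobutyl chain. A primary amide, a carboxylic acid or an aminomethyl group on the same carbon could help separate the two.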